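The source may report more compounds than this note shows. Statements on the series, on what has been measured and on what is new or still open speak of the compounds shown alone.

Series notes, sulfonamide anilines on a shared pyrimidine core.

Compound 1 `Cc1ccc(NS(=O)(=O)c2ccc(Cl)cc2)cc1Nc1nccc(-c2cccnc2)n1` carries a chloro group on the aromatic ring attached to the sulfonyl sulfur; in a functional assay on MCF7 cells (Homo sapiens) for cytotoxicity, read by MTT assay, with a stated time of 24 h (a lower number here means a stronger inhibitor, a higher number a weaker inhibitor), compound 1 gives 11800 nM. Compound 2 `Cc1ccc(NS(=O)(=O)c2ccc(-c3ccccc3)cc2)cc1Nc1nccc(-c2cccnc2)n1` has a phenyl in place of that chloro; in this assay compound 2 gives 11900 nM. The step of a 1.0-fold higher number from compound 1 to compound 2 (0.00 log units; within the scatter) is the only one measured so far, and it shows that swapping the chloro for a phenyl on that aromatic carbon leaves the read-out unchanged within the scatter, so compound 2 and compound 1 stand together, with no difference that can be read as an order.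

Compound 3 `Cc1ccc(NS(=O)(=O)c2ccc3ccccc3c2)cc1Nc1nccc(-c2cccnc2)n1` differs from compound 2 by naphthalen-2-yl in place of 4-phenylphenyl on a sulfonyl sulfur. Among the compounds with values here, the one measured step that touches this part of the molecule, a 1.0-fold higher number from compound 1 to compound 2 (0.00 log units; within the scatter), was flat, and the change from 4-phenylphenyl to naphthalen-2-yl again keeps two six-membered aromatic carbon rings with no donor or acceptor, so no step beyond the scatter is expected in this assay. The expected step is a 1.0-fold higher number from compound 2 to compound 3 (0.00 log units; within the scatter). Compound 3 is therefore estimated at 12000 nM in this assay, with a range from 5000 nM to 30000 nM.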

Compound 3, half-maximal inhibitory concentration: 12000 nM
Compound 3: middle estimate and measured number agree at the digits printed, and the stated range covers the measured number.
By their numbers in this assay, from the lowest: compounds 1, 2 and 3 (each within the scatter of the next).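

Within this assay, the flat result now extends beyond a single swap on an aromatic carbon: the whole group on the sulfonyl sulfur was replaced, and the step of a 1.0-fold higher number from compound 2 to compound 3 (0.00 log units; within the scatter) shows no difference that can be read, even though naphthalen-2-yl holds fewer heavy atoms than 4-phenylphenyl. The step of a 1.0-fold higher number from compound 1 to compound 3 (0.01 log units; within the scatter) gives the same reading for naphthalen-2-yl in place of 4-chlorophenyl, so the three groups on the sulfonyl sulfur stand together in this assay, with no order among them. No supporting measurement is available to account for this flatness.

The groups compared so far are all aromatic, with no hydrogen-bond donor or acceptor in the two that were counted, so the series does not yet say whether a carboxylic acid or an amine on that aromatic ring would shift the number. On these data alone, a straight butyl chain directly on the sulfonyl sulfur is equally open, as is any change to the sulfonamide nitrogen or the shared core, and the present compounds cannot show whether this read-out responds to any change at all.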